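Fluorophenyl in place of methoxyphenyl on the piperazine nitrogen

The source may hold more compounds than are shown below. What is called first, only, known or untested is meant among the compounds shown, and "the series" means these compounds.

Within the data shown here, compound 3 `COc1ccccc1N1CCN(C(=O)CN2C(=O)CC(C)(c3ccccc3)C2=O)CC1` was examined in a functional assay on the whole organism (strain CD-1) with Mus musculus as the target, with a stated time of 0.5 h (on this read-out higher numbers stand for an effect only at larger amounts of compound and lower numbers for an effect already at smaller amounts), and was reported as "not active" (no number reported), so no number stands for it and no step from compound 3 to any other compound can be sized. The two compounds with numbers carry other groups on the same ring nitrogen: in this assay compound 1 `CC1(c2ccccc2)CC(=O)N(CC(=O)N2CCN(c3ccccc3F)CC2)C1=O` gives 100 mg/kg, and compound 2 `CC1(c2ccccc2)CC(=O)N(CC(=O)N2CCN(c3ccccc3)CC2)C1=O` gives 100 mg/kg. The step of no change at the digits printed from compound 1 to compound 2 (within the scatter) is the only measured one that bears on the change studied here, and it lies within the scatter.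

Compound 4 `CC1(c2ccccc2)CC(=O)N(CC(=O)N2CCN(c3ccc(F)cc3)CC2)C1=O` differs from compound 3 as follows: 4-fluorophenyl in place of 2-methoxyphenyl on an amine nitrogen in a ring. The fluorine that enters recalls compound 1, which also carries a fluoro on an aromatic carbon, while compound 2 carries none; both gave the same figure. Nothing in these data separates the 4-fluorophenyl from a plain phenyl, and the methoxy that leaves is the group of the inactive compound 3. The expectation for compound 4 is therefore a value in the region of compounds 1 and 2 rather than no activity, though the result for compound 3 leaves a real chance that compound 4 is also reported without a number. Compound 4 is expected to give about 100 mg/kg in this assay, within a range from 50 mg/kg to 300 mg/kg.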

Compound 4, minimum effective dose: "not active" (no number reported)
Nothing numeric was reported for compound 4; the estimate stays without a comparison.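

Compound 3 and compound 4 were both reported without a number in this assay, so no step can be read between them, nor from compound 4 to any other compound. Nothing shown here accounts for this result. The compounds shown leave open what separates compound 4 from compound 1 and compound 2, which both received numbers.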